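This account rests on a few compounds, and the source may have more. Where it says the series, first, only, none or still open, it means among the compounds named here.

Compound 3 `O=S(=O)(NCCCNCc1ccccc1)c1cc(C(F)(F)F)cc(C(F)(F)F)c1` gives 3000 nM in a functional assay on MCF7 cells (Homo sapiens) for inhibition, read by MTT assay, with a stated time of 72 h; a lower number here means a stronger inhibitor of growth, a higher number a weaker inhibitor of growth. On the numbers shown it stands second highest of three, with compound 1 `O=S(=O)(NCCCNCc1ccc(Cl)c(C(F)(F)F)c1)c1cc(C(F)(F)F)cc(C(F)(F)F)c1` giving 3500 nM and compound 2 `O=S(=O)(NCCCNCC1COc2ccccc2O1)c1cc(C(F)(F)F)cc(C(F)(F)F)c1` giving 2500 nM, all within the scatter of one another. Compound 4 `O=S(=O)(NCCCNCc1ccc(Br)cc1)c1cc(C(F)(F)F)cc(C(F)(F)F)c1` differs from compound 3 by bromo in place of hydrogen on an aromatic carbon. The step that bears most on this change is a 1.2-fold lower number from compound 1 to compound 3 (0.07 log units; within the scatter), where replacing substituted benzyl by plain benzyl gave no step beyond the scatter; the steps of a 1.4-fold lower number from compound 1 to compound 2 (0.15 log units; within the scatter) and a 1.2-fold higher number from compound 2 to compound 3 (0.08 log units; within the scatter) were likewise within the scatter. Adding a bromo group to the benzyl ring is therefore expected to bring no step beyond the scatter in this assay. Compound 4 is expected to give 3000 nM, in a range from 1500 nM to 6000 nM. This amounts to an expected step of no change at the digits printed from compound 3 to compound 4 (within the scatter).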

Compound 4, concentration for 50% growth inhibition: 1900 nM
For compound 4 the middle estimate is 1.6-fold (0.20 log units) above the measured one, and the stated range covers the measured number.
By their numbers in this assay, from the lowest: compounds 4, 2, 3 and 1 (each within the scatter of the next).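

In this assay, bromo in place of hydrogen on an aromatic carbon, para to a large group, stays within the scatter, with a 1.6-fold lower number from compound 3 to compound 4 (0.20 log units; within the scatter). Against the other two compounds it also stays within the scatter, with a 1.3-fold lower number from compound 2 to compound 4 (0.12 log units; within the scatter) and a 1.8-fold lower number from compound 1 to compound 4 (0.27 log units; within the scatter), so this ring position has not yet given a step beyond the scatter. No measurement here bears on the reason for these numbers.

As far as these compounds go, whether a methoxy group or a carboxylic acid at this ring position, or a longer chain between the two nitrogens, would give a step beyond the scatter stays open.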